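The source may hold more compounds than are shown below. What is called first, only, known or untested is meant among the compounds shown, and "the series" means these compounds.

Compound 1 `Cc1ccc(S(=O)(=O)n2cc(COC3=C/C(=N\c4ccccc4)c4ccccc4C3=O)nn2)cc1` gives 5370 nM
Compound 2 `Cc1ccc(S(=O)(=O)n2cc(COC3=C/C(=N\c4ccc(Br)cc4)c4ccccc4C3=O)nn2)cc1` gives 9250 nM

In a functional assay on HCT-116 cells (Homo sapiens) for cytotoxicity, read by MTT assay, with a stated time of 72 h (a higher number here means a weaker inhibitor, a lower number a stronger inhibitor), compound 2 gives 9250 nM and sits within the scatter of compound 1, so the two cannot be ranked. The next compound to be tested is compound 3 `COc1ccc(/N=C2\C=C(OCc3cn(S(=O)(=O)c4ccc(C)cc4)nn3)C(=O)c3ccccc32)cc1` and it differs from compound 2 in one place methoxy in place of bromo on an aromatic carbon with methoxy in place of bromo on an aromatic carbon. The rest of the molecule stays the same.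

Going by the values given here, only one measured step bears on this change. It is a 1.7-fold higher number from compound 1 to compound 2 (0.24 log units; within the scatter) for bromo in place of hydrogen on an aromatic carbon, and it stays within the scatter. Among the compounds with values here, no compound carrying methoxy has been measured yet, so this single step is only thin guidance. Even so, nothing in the two measured values points to a large shift in this assay for compound 3.

The expected step is a 1.3-fold lower number from compound 2 to compound 3 (0.12 log units; within the scatter) and it would stay within the scatter. For compound 3 the estimate is 7000 nM with an expected range of 3000 nM to 16000 nM in this read-out.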

Compound 3, half-maximal inhibitory concentration: 7430 nM
The estimate for compound 3 lay 1.1-fold (0.03 log units) below the measured number; measured number inside the range.
By their numbers in this assay, from the lowest: compounds 1, 3 and 2 (each within the scatter of the next).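

In this assay, the swap from 4-bromophenyl to 4-methoxyphenyl gives a 1.2-fold lower number from compound 2 to compound 3 (0.10 log units; within the scatter) and the same methoxy group measured against the unsubstituted compound gives a 1.4-fold higher number from compound 1 to compound 3 (0.14 log units; within the scatter) for methoxy in place of hydrogen. This place on the aromatic ring has now carried hydrogen, bromo and methoxy, and every pair among the three compounds lies within the scatter, so none of these groups can be ranked above another here. Methoxy differs from bromo in having two heavy atoms rather than one and in bringing one hydrogen-bond acceptor, yet this difference in make-up gives no separation in the cell read-out.

Going by these compounds, whether an amine, a carboxylic acid or a longer chain such as butoxy at this same place would move the number beyond the scatter remains open. Also open, on these data alone, is whether changes elsewhere on the shared core would matter more, since all three compounds keep the rest of the molecule unchanged and differ only at this one place. No outside measurement is available to account for how closely these three values fall together.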